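A few compounds are considered here, and "the series" means these few. Any claim that something is new, unique, unknown or untested is made for them only; others in the source may bear on it.

Measured so far in an assay on membranes from brain for inhibition of Fatty-acid amide hydrolase 1 (Rattus norvegicus); a lower number here means a stronger inhibitor, a higher number a weaker inhibitor:
compound 1 `CCCCCCCCCCC[C@@H](C[C@@H]1OC(=O)[C@H]1CCCCCC)OC(=O)CCC(C)C` gives 10400 nM;
compound 2 `CCCCCCCCCCC[C@@H](C[C@@H]1OC(=O)[C@H]1CCCCCC)OC(=O)[C@@H](NC(C)=O)C(C)CC` gives 6600 nM.

Of the two numbers, compound 2 stands with compound 1 inside the usual scatter, the difference being a 1.6-fold lower number from compound 1 to compound 2 (0.20 log units; within the scatter). Compound 3 `CCCCCCCCCCC[C@@H](C[C@@H]1OC(=O)[C@H]1CCCCCC)OC(=O)[C@@H]1CCCN1C=O` arises from compound 2 by 1-formylpyrrolidin-2-yl in place of 1-acetamido-2-methylbutyl on a carbonyl carbon. Among the measured compounds shown here, the only measured step that bears on this change is the exchange of the acyl group on the same carbonyl carbon, a 1.6-fold lower number from compound 1 to compound 2 (0.20 log units; within the scatter), which stayed within the scatter. Compound 3 is therefore expected to show no step beyond the scatter in this assay, namely a 1.0-fold lower number from compound 2 to compound 3 (0.01 log units; within the scatter). Compound 3 is estimated at 6500 nM, between 2200 nM and 20000 nM.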

Compound 3, half-maximal inhibitory concentration: 3400 nM
Beside the measured number, compound 3's estimate is 1.9-fold (0.28 log units) above it; the range from low to high includes it.
By their numbers in this assay, from the lowest: compounds 3, 2 and 1 (each within the scatter of the next, the first and the last beyond it).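

In this assay the group on this carbonyl carbon now yields a step beyond the scatter, with a 3.1-fold lower number from compound 1 to compound 3 (0.49 log units; beyond the scatter) when 1-formylpyrrolidin-2-yl replaces isopentyl. By contrast, a 1.9-fold lower number from compound 2 to compound 3 (0.29 log units; within the scatter) leaves 1-formylpyrrolidin-2-yl and 1-acetamido-2-methylbutyl unseparated, even though the former has a five-membered ring and no hydrogen-bond donor. Nothing available accounts for either step. The compounds shown leave open whether the formyl group itself matters, since no free pyrrolidine amine or acetyl group on that ring nitrogen appears among them. They also leave open how a carboxylic acid on the ring would read here.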